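The source may hold more compounds than are shown below. What is called first, only, known or untested is meant among the compounds shown, and "the series" means these compounds.

The series shares one core, seen in compound 1 `Cc1ccc(CC(C)CNC(=O)/N=C(\N)NCCCc2sc(N)nc2C)cc1`, which in an assay on membranes from Sf9 cells for displacement of a labelled ligand from histamine H2 receptor (Homo sapiens), read by scintillation counting, with a stated time of 60 min (on this read-out higher numbers stand for weaker inhibition and lower numbers for stronger inhibition), gives 72.4 nM. Compound 2 `Cc1nc(N)sc1CCCN/C(N)=N/C(=O)N[C@@H](C)c1ccccc1` gives 51.3 nM in this assay, and compound 3 `Cc1nc(N)sc1CCCN/C(N)=N/C(=O)NC(C)c1ccc(Cl)cc1` gives 46.8 nM in this assay. Compound 1 carries the highest of the three numbers, yet its gap to compound 2 and its gap to compound 3 both lie within the usual scatter of repeated measurements, so the three compounds cannot be told apart on these numbers.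

Compound 4 `Cc1nc(N)sc1CCCN/C(N)=N/C(=O)NCC(C)CCCc1ccccc1` has not yet been measured in this assay. It differs from compound 1 in one place: phenethyl in place of 4-methylphenyl on a saturated chain carbon, three bonds along the chain from an amide-type nitrogen. The aromatic ring stays, the methyl on it is lost, and the link to the saturated chain is lengthened.

Within the data shown here, no pair of measured compounds separated by a single change is at hand, so the size of this step has no measured counterpart. The account expects little movement: the step of a 1.2-fold higher number from compound 1 to compound 4 (0.09 log units; within the scatter) is estimated to stay within the scatter, with a mild lean toward a higher number. Compound 4 is therefore expected to give about 90 nM in this assay, within a range of 35 nM to 250 nM.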

Compound 4, inhibition constant: 60.3 nM
Estimate against measurement, compound 4: 1.5-fold (0.17 log units) above; measured number inside the range.
By their numbers in this assay, from the lowest: compounds 3, 2, 4 and 1 (each within the scatter of the next).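

In this assay, among these compounds, the pair offers the first single change that can be read, and at this position, on a saturated chain carbon, three bonds along the chain from an amide-type nitrogen, the swap of 4-methylphenyl for phenethyl gives a 1.2-fold lower number from compound 1 to compound 4 (0.08 log units; within the scatter) as its step. The same difference, read as 4-methylbenzyl to 3-phenylpropyl, therefore shows that the loss of the ring methyl together with the longer link to the chain leaves compound 4 not distinguishable from compound 1 on this read-out. Nothing on hand explains this result or separates the part played by the methyl from that of the link.

This is one step at one position, so it cannot be said whether the same holds for other groups there. On these data alone, an end group without the aromatic ring, such as an amine or a carboxylic acid in place of phenethyl, remains open, as does a longer chain carrying the same phenyl ring.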